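The source may report more compounds than this note shows. Statements on the series, on what has been measured and on what is new or still open speak of the compounds shown alone.

Measured so far:
compound 1 `Cc1c(OCC2=NCCN2)ccc(Cl)c1NS(C)(=O)=O` gives 60%
compound 2 `Cc1ccc2c(c1NS(C)(=O)=O)CCC2c1ncc[nH]1` gives 83%
compound 3 `Cc1oncc1-c1cccc2c1CCC2c1ncc[nH]1` gives 63%

All three were run in a functional assay on CHO cells for agonist activity at Alpha-1A adrenergic receptor (Homo sapiens), read by FLIPR and calcium flux; a lower number here means a smaller maximal response, a higher number a larger maximal response. On these three numbers compound 3 stands second highest. Its nearest neighbour is compound 1, whose value lies lower by a gap that is within the scatter, so the two cannot be ranked against each other. Compound 2 lies furthest off, higher by a gap that is beyond the scatter; compound 2 therefore reaches a larger maximal response than compound 3.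

Among the measured compounds shown here, no pair of measured compounds differs in a single place, so no step from one measured compound to another is available to set a scale for the next change.

Compound 4 `Cn1nccc1-c1cccc2c1CCC2c1ncc[nH]1` has not yet been measured in this assay. It differs from compound 3 in one place: 1-methyl-1H-pyrazol-5-yl in place of 5-methyl-1,2-oxazol-4-yl on an aromatic carbon. The group that leaves and the group that enters are of the same size, each a five-membered aromatic ring with two hetero atoms, and each without hydrogen-bond donors and with two hydrogen-bond acceptors. For the measured compounds named here, with no comparable step on record, the expectation is that the change from compound 3 to compound 4 produces no step beyond the scatter in this assay, in either direction, that is a number 3 percentage points lower from compound 3 to compound 4 (within the scatter). Compound 4 is accordingly estimated at 60%, in a range from 40% to 80%.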

Compound 4, largest response reached (Emax), in percent of the reference or control that the assay uses: 58%
Compound 4: the middle estimate sits 2 percentage points above what was measured; low and high end bracket the measured number.
By their numbers in this assay, from the lowest: compounds 4, 1 and 3 (each within the scatter of the next); then compound 2.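

In this assay, among the compounds shown here, 1-methyl-1H-pyrazol-5-yl in place of 5-methyl-1,2-oxazol-4-yl on an aromatic carbon gives a number 5 percentage points lower from compound 3 to compound 4 (within the scatter) and is the first step that isolates a single place. For the compounds shown here, it therefore gives a first reading at this position: these two five-membered aromatic rings, one holding two nitrogens and the other a nitrogen and an oxygen, match in heavy atoms and hydrogen-bond counts and are not told apart by the maximal response. No measurement at hand bears on why the two groups read alike, and this one step sets no scale for a change of another kind.

Still open, as far as these compounds go, is how the maximal response moves when a group of a different kind stands on this aromatic carbon, such as a pyridine ring, a phenyl ring, an amine or a carboxylic acid. Also open, from the compounds shown here alone, is whether the swap of these two rings would read the same way with other substituents on the shared core.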